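Benzylation of the ring amine in compound 3

The source may hold more compounds than are shown below. What is called first, only, known or untested is meant among the compounds shown, and "the series" means these compounds.

Compound 3 `N#C[C@@H]1CCCN1C(=O)[C@@H]1C[C@H](N)CN1` gives 9.1 nM in an assay on isolated protein for inhibition of Dipeptidyl peptidase 4 (Rattus norvegicus); on this read-out higher numbers stand for weaker inhibition and lower numbers for stronger inhibition. This is the highest of the three numbers in hand: the parent compound 1 `N#C[C@@H]1CCCN1C(=O)[C@@H]1CCCN1` gives 2.9 nM, and compound 2 `N#C[C@@H]1CCCN1C(=O)[C@@H]1C[C@H](Nc2ccccc2)CN1` gives 0.53 nM. The step of a 3.1-fold higher number from compound 1 to compound 3 (0.50 log units; beyond the scatter) is modest, the step of a 17-fold higher number from compound 2 to compound 3 (1.23 log units; beyond the scatter) is large, and the step of a 5.5-fold lower number from compound 1 to compound 2 (0.74 log units; beyond the scatter) is modest in the other direction.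

Compound 4 `N#C[C@@H]1CCCN1C(=O)[C@@H]1C[C@H](NCc2ccccc2)CN1` differs from compound 3 by benzyl in place of hydrogen on an amine nitrogen. The step that bears most directly on this change is the reverse of a 17-fold higher number from compound 2 to compound 3 (1.23 log units; beyond the scatter), in which a phenyl on that same amine nitrogen went with the much lower number. Benzyl is not phenyl, and no measured pair in this set contains a benzyl, so the size of the effect is uncertain; a substantial lowering is expected, though not necessarily a full return to the level of compound 2. The estimate for compound 4 in this assay is 1.2 nM with a range of 0.4 nM to 4 nM, which corresponds to an expected step of a 7.6-fold lower number from compound 3 to compound 4 (0.88 log units; beyond the scatter).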

Compound 4, half-maximal inhibitory concentration: 3 nM
Beside the measured number, compound 4's estimate is 2.5-fold (0.40 log units) below it, and the stated range covers the measured number.
By their numbers in this assay, from the lowest: compound 2; then compounds 1 and 4 (each within the scatter of the next); then compound 3.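

Read on this assay the change of hydrogen to benzyl on the amine nitrogen gives a 3.0-fold lower number from compound 3 to compound 4 (0.48 log units; beyond the scatter) and so shows that phenyl is not the only group on this nitrogen that goes with a lower number than the free amine. Benzyl in place of phenyl gives a 5.7-fold higher number from compound 2 to compound 4 (0.75 log units; beyond the scatter) and shows that the size of the lowering depends on which of these two groups is present. Nothing measured here gives a reason for either step.

Going by these compounds, whether a longer chain such as phenethyl on this nitrogen would raise the number further remains open. Also open, on these data alone, is whether a small alkyl group such as methyl, with no aromatic ring, would lower the number relative to the free amine.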